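Working notes: from compound 3 to compound 4

The source may report more compounds than this note shows. Statements on the series, on what has been measured and on what is new or still open speak of the compounds shown alone.

In a functional assay on MDA-MB-231 cells (Homo sapiens) for inhibition, read by MTT assay, with a stated time of 48 h (a higher number here means a weaker inhibitor of growth, a lower number a stronger inhibitor of growth), compound 1 (`S=C(Nc1ccc(Cl)cc1)Nc1ccc2ncnc(Nc3cccc(Br)c3)c2c1`) gives 8200 nM, compound 2 (`Oc1ccc(NC(=S)Nc2ccc3ncnc(Nc4cccc(Br)c4)c3c2)cc1`) gives 17300 nM and compound 3 (`FC(F)(F)c1ccc(NC(=S)Nc2ccc3ncnc(Nc4cccc(Br)c4)c3c2)cc1`) gives 12200 nM. Compound 3 lies within the scatter of both other compounds, with steps of a 1.5-fold higher number from compound 1 to compound 3 (0.17 log units; within the scatter) and a 1.4-fold lower number from compound 2 to compound 3 (0.15 log units; within the scatter).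

Compound 4 (`S=C(Nc1ccc(Cl)c(Cl)c1)Nc1ccc2ncnc(Nc3cccc(Br)c3)c2c1`) carries 3,4-dichlorophenyl in place of 4-(trifluoromethyl)phenyl on an amide-type nitrogen.

The closest evidence is the exchange of chloro and trifluoromethyl between compound 1 and compound 3, which stays within the scatter in a 1.5-fold higher number from compound 1 to compound 3 (0.17 log units; within the scatter). For the measured compounds named here, the only step beyond the scatter, a 2.1-fold higher number from compound 1 to compound 2 (0.32 log units; beyond the scatter), is modest and involves hydroxy, which compound 4 does not carry. Going by the values given here, no measured compound shows what a second chloro does on this ring, so that part of the change remains untested.

An estimated 1.3-fold lower number from compound 3 to compound 4 (0.11 log units; within the scatter) is expected in this assay, so no clear change is anticipated. Compound 4 is expected at 9500 nM, with an estimated range of 4500 nM to 19000 nM.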

Compound 4, concentration for 50% growth inhibition: 4800 nM
The estimate for compound 4 lay 2.0-fold (0.30 log units) above the measured number; measured number inside the range.
By their numbers in this assay, from the lowest: compounds 4, 1, 3 and 2 (each within the scatter of the next, the first and the last beyond it).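

In this assay, the aryl group on the amide-type nitrogen now gives steps beyond the scatter that involve no hydroxy on one side only: 3,4-dichlorophenyl in place of 4-(trifluoromethyl)phenyl gives a 2.5-fold lower number from compound 3 to compound 4 (0.41 log units; beyond the scatter) and 3,4-dichlorophenyl in place of 4-hydroxyphenyl gives a 3.6-fold lower number from compound 2 to compound 4 (0.56 log units; beyond the scatter) as well. For the compounds shown here, the first direct reading of a second chloro on this ring, chloro in place of hydrogen, gives a 1.7-fold lower number from compound 1 to compound 4 (0.23 log units; within the scatter) and so cannot be told from no change. Nothing available here explains the size of these steps.

Still open, as far as these compounds go, is how an amine or a carboxylic acid on this phenyl ring would compare with the chloro and trifluoromethyl groups. Also open, from the compounds shown here alone, is what a longer chain, such as hexyl, would give in place of the phenyl ring on the amide-type nitrogen.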